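Flat series: aryl swap on the alkene carbon

The compounds below may be only part of what the source reports. "The series", "measured", "known", "first", "only" and "open" are said of these compounds alone.

Compound 2 `CSc1ccc(/C=C(\C(=O)c2ccc(Cl)cc2)S(=O)(=O)Cc2ccc(C)cc2)cc1` is measured in a functional assay on DU-145 cells (Homo sapiens) for inhibition, read by trypan blue exclusion, with a stated time of 96 h (on this read-out lower numbers stand for stronger inhibition of growth and higher numbers for weaker inhibition of growth), where compound 2 gives 10000 nM. Two neighbours differ from it in one place. Compound 1 `CSc1ccc(/C=C(\C(=O)c2ccc(Cl)cc2)S(=O)(=O)Cc2ccc(Cl)cc2)cc1` carries chloro where compound 2 carries methyl; in this assay compound 1 gives 10000 nM, and the step of no change at the digits printed from compound 1 to compound 2 (within the scatter) is methyl in place of chloro on an aromatic carbon. Compound 3 `CSc1ccc(/C=C(\C(=O)c2ccc(Br)cc2)S(=O)(=O)Cc2ccc(C)cc2)cc1` carries bromo where compound 2 carries chloro; in this assay compound 3 gives 10000 nM, and the step of no change at the digits printed from compound 2 to compound 3 (within the scatter) is bromo in place of chloro on an aromatic carbon. Compound 2 therefore stands level with compound 1 and compound 3, with nothing separating the three beyond the scatter.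

Compound 4 `Cc1ccc(CS(=O)(=O)/C(=C/c2cc(C)cc(C)c2)C(=O)c2ccc(Cl)cc2)cc1` is the compound not yet measured. Its difference from compound 2: 3,5-dimethylphenyl in place of 4-(methylsulfanyl)phenyl on a double-bonded chain carbon bound to a double-bonded chain carbon

Within the data shown here, the two measured steps touch only the halogen or methyl on aromatic carbons and both left the read-out unchanged; neither addresses the aryl group on the double-bonded chain carbon, so there is no directly relevant precedent. With every measured value sitting at the same level, the expectation for compound 4 is a step of no change at the digits printed from compound 2 to compound 4 (within the scatter) of no size beyond the scatter. Compound 4 is estimated at 10000 nM in this assay, within a range from 5000 nM to 20000 nM.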

Compound 4, concentration for 50% growth inhibition: 10000 nM
Compound 4: middle estimate and measured number agree at the digits printed; measured number inside the range.
By their numbers in this assay, from the lowest: compounds 1, 2, 3 and 4 (each within the scatter of the next).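

In this assay, among these compounds, the step, no change at the digits printed from compound 2 to compound 4 (within the scatter), is the first one at the aryl group on a double-bonded chain carbon bound to a double-bonded chain carbon; the earlier steps touched only chloro, methyl and bromo on aromatic carbons. At this place, 3,5-dimethylphenyl and 4-(methylsulfanyl)phenyl, each with 8 heavy atoms and one six-membered aromatic ring of carbon only, stand level, so this read-out does not separate a group holding sulfur and 1 hydrogen-bond acceptor from an all-carbon group with 0 hydrogen-bond acceptors. Nothing measured on these compounds offers an explanation for this flat result.

All the steps shown lie within the scatter, so the series does not yet identify any structural change that moves growth inhibition in this assay. From the compounds shown here alone, whether a phenyl group carrying an amine or a carboxylic acid at this place would separate from compound 2 stays open, as does the outcome of replacing the aryl group here with a longer alkyl chain.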